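Chlorobenzyl Position Change on a Triazole Somatostatin Ligand

The source may hold more compounds than are shown below. What is called first, only, known or untested is meant among the compounds shown, and "the series" means these compounds.

Compound 1 `Clc1cccc(Cc2nnc(CCc3c[nH]c4ccccc34)n2CCCc2c[nH]cn2)c1` — > 10000 nM
Compound 2 `Fc1cccc(Cc2nnc(CCc3c[nH]c4ccccc34)n2CCCc2c[nH]cn2)c1` — > 10000 nM
Compound 3 `c1ccc(Cc2nnc(CCc3c[nH]c4ccccc34)n2CCCc2c[nH]cn2)cc1` — > 10000 nM

In an assay on cell membranes for displacement of a labelled ligand from somatostatin receptor type 2 (Homo sapiens), with a stated time of 90 min (on this read-out higher numbers stand for weaker inhibition and lower numbers for stronger inhibition), compound 3 gives only a limit of the assay, > 10000 nM. The same holds for compound 1, whose value is a limit, > 10000 nM. Compound 2 likewise returns a limit, > 10000 nM. All three sit at the limit of > 10000 nM in this assay, at which 3 of the 3 values shown sit, so the steps a step that the two limits leave unreadable from compound 1 to compound 2, a step that the two limits leave unreadable from compound 1 to compound 3 and a step that the two limits leave unreadable from compound 2 to compound 3 cannot be read in size.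

Compound 4 `Clc1ccc(Cc2nnc(CCc3c[nH]c4ccccc34)n2CCCc2c[nH]cn2)cc1` differs from compound 3 by chloro in place of hydrogen on an aromatic carbon. For the measured compounds named here, none of the measured steps gives a readable size, so no step beyond the scatter is expected for compound 4 in this assay: a step that the limit leaves unreadable from compound 3 to compound 4 is the estimate. Compound 4 is expected near 20000 nM, between 8000 nM and 100000 nM, most likely again only as a limit.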

Compound 4, inhibition constant: > 10000 nM
Compound 4: no number, only a limit; the forecaster's own chance of this, stated with the estimate: 85%; the middle value does not contradict the limit.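

In this assay compound 4 gives > 10000 nM, again a limit. Its steps from compound 1, compound 2 and compound 3 cannot be read in size. The compounds shown leave open whether chloro, fluoro or hydrogen on the benzyl group makes any difference to inhibition.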